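The compounds below may be only part of what the source reports. "The series", "measured", "known", "first", "only" and "open" are said of these compounds alone.

Measured compounds in an assay on isolated protein for displacement of a labelled ligand from metabotropic glutamate receptor 5 (Homo sapiens), with a stated time of 60 min, tested at 1 uM; a higher number here means more inhibition at the concentration tested (going by the name of the read-out), a lower number less inhibition:
compound 1 `COc1ccc(S(=O)(=O)c2cnc3cc(F)ccc3c2N2CCC(C)CC2)cc1` gives 90%
compound 2 `O=S(=O)(c1ccccc1)c1cnc2ccccc2c1N1CCCCCC1` gives 79.9%
compound 3 `Cc1ccc2ncc(S(=O)(=O)c3ccc(F)c(Cl)c3)c(N3CCC(C)CC3)c2c1` gives 93%

Compound 1 stands second highest of the three numbers in this assay. Compound 3 sits within the scatter of compound 1; compound 2 lies beyond the scatter below compound 1. The numbers of compound 1 and compound 3 are level within the scatter.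

Compound 4 `CC1CCN(c2c(S(=O)(=O)c3cc(Cl)cc(Cl)c3)cnc3cc(F)ccc23)CC1` has not been measured. It differs from compound 1 in one place: 3,5-dichlorophenyl in place of 4-methoxyphenyl on a sulfonyl sulfur. Going by the values given here, no measured pair in the set shows this exact change, so no step between measured compounds can be drawn on. Compound 3, carrying a 3-chloro-4-fluorophenyl on its sulfonyl sulfur, gives 93%, a number within the scatter of compound 1, which suggests a halogenated ring in this place keeps the inhibition high.

For compound 4 the expected step is a number 2 percentage points lower from compound 1 to compound 4 (within the scatter), none beyond the scatter. Compound 4 is estimated at 88%, in the range 72% to 97%.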

Compound 4, a percentage reported as inhibition, at one concentration (the size of the read-out at that concentration, not a potency): 87%
Estimate against measurement, compound 4: 1 percentage points above; the range from low to high includes it.
By their numbers in this assay, from the lowest: compounds 2, 4, 1 and 3 (each within the scatter of the next, the first and the last beyond it).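

In this assay, going by these compounds alone, the first direct step at this position, 3,5-dichlorophenyl in place of 4-methoxyphenyl on a sulfonyl sulfur, gives a number 3 percentage points lower from compound 1 to compound 4 (within the scatter) with the rest of compound 1 unchanged. The methoxy oxygen is therefore not required to keep inhibition high at the concentration tested. No measurement available bears on why the step stays this small.

Still open, on these data alone, is whether an amine or a carboxylic acid on this phenyl ring would keep the inhibition. As far as these compounds go, a reading at one concentration is also not a potency, so any potency difference between these compounds remains unknown.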